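This account rests on a few compounds, and the source may have more. Where it says the series, first, only, none or still open, it means among the compounds named here.

Measured so far in a toxicity assay on THP-1 cells (Homo sapiens) for inhibition; on this read-out lower numbers stand for higher toxicity in this test and higher numbers for lower toxicity in this test:
Compound 1, `COc1ccc(-c2cnc(NC(=O)c3cnc[nH]3)n2C)cc1`, gives > 100000 nM, which is a limit.
Compound 2, `COc1ccc(-c2cnc(NC(=O)c3cccc(F)c3)n2C)cc1`, gives > 100000 nM, which is a limit.
Compound 3, `COc1ccc(-c2cnc(NC(=O)c3cccc(Cl)c3)n2C)cc1`, gives > 28000 nM, which is a limit.

Compound 3 stands at the limit of > 28000 nM in this assay, at which 1 of the 3 values shown sits, while compounds 1 and 2 stand at the limit of > 100000 nM in this assay, at which 2 of the 3 values shown sit. Among the compounds with values here, none of the measured steps can be read: a step that the two limits leave unreadable from compound 1 to compound 3, a step that the two limits leave unreadable from compound 2 to compound 3 and a step that the two limits leave unreadable from compound 1 to compound 2 are all unreadable. Compound 4 is `COc1ccc(-c2cnc(NC(=O)c3ccno3)n2C)cc1`. Its change from compound 3: 1,2-oxazol-5-yl in place of 3-chlorophenyl on a carbonyl carbon. This exchange of a carbon-only aromatic ring for a five-membered aromatic ring with hetero atoms has no readable counterpart among the measured steps. No step beyond the scatter in this assay is therefore expected; the expected step is a step that the limit leaves unreadable from compound 3 to compound 4. Compound 4 is estimated at 100000 nM, within 28000 nM to 300000 nM, most likely reported again as a limit.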

Compound 4, half-maximal cytotoxic concentration: > 100000 nM
Compound 4 gave a limit, no number; the forecaster's own chance of this, stated with the estimate: 80%; the middle value sits exactly at the limit.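

In this assay compound 4 gives > 100000 nM, which is a limit, so its steps from compound 1, compound 2 and compound 3 cannot be read. As far as these compounds go, whether any exchange on the carbonyl carbon shifts toxicity in this test stays open: every value shown is a limit.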